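The compounds below may be only part of what the source reports. "The series", "measured", "known", "first", "only" and "open" are said of these compounds alone.

Compound 1 `Oc1cccc(-c2cc(-c3ccsc3)cc(-c3ccccc3O)n2)c1` gives in a functional assay on DU-145 cells (Homo sapiens) for cytotoxicity, read by CCK-8 assay (a higher number here means a weaker inhibitor, a lower number a stronger inhibitor), a result that is only a limit of the assay, > 50000 nM. Compound 2 `Oc1ccc(-c2cc(-c3ccsc3)cc(-c3ccccc3O)n2)cc1` likewise stops at a limit in this assay, > 50000 nM. Compound 3 `Oc1cccc(-c2cc(-c3ccsc3)cc(-c3cccc(O)c3)n2)c1` gives 1310 nM in this assay. Of the measured steps, a step that the two limits leave unreadable from compound 1 to compound 2, and an at least 38-fold lower number from compound 1 to compound 3 (1.58 log units; beyond the scatter); both concern the hydroxyphenyl groups and neither touches the five-membered ring. Compound 4 `Oc1cccc(-c2cc(-c3ccoc3)cc(-c3ccccc3O)n2)c1` differs from compound 1 by furan-3-yl in place of thiophen-3-yl on an aromatic carbon. Within the data shown here, because of the limit of > 50000 nM in this assay, at which 2 of the 3 values shown sit, compound 1 supplies no number from which a step can be read, and the change from thiophen-3-yl to furan-3-yl has no measured counterpart. The expectation for compound 4 is therefore that it remains near the limit, a step of a number no higher from compound 1 to compound 4 (the limit leaves the size open). The estimate for compound 4 in this assay is 50000 nM, with a range from 10000 nM to 200000 nM.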

Compound 4, half-maximal inhibitory concentration: 2790 nM
The estimate for compound 4 lay 18-fold (1.25 log units) above the measured number; the whole stated range lies above it.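

In this assay, the position opposite the ring nitrogen can move the read-out: furan-3-yl in place of thiophen-3-yl gives an at least 17-fold lower number from compound 1 to compound 4 (1.25 log units; beyond the scatter). The earlier steps shown here concerned only the hydroxyphenyl groups, whereas here the five-membered ring alone changes, with the 2-hydroxyphenyl group kept. The true size of this step stays unknown, since compound 1 gives only a limit of the assay: the limit of > 50000 nM in this assay, at which 2 of the 4 values shown sit.

From the compounds shown here alone, whether furan-3-yl would also lower the number alongside the two 3-hydroxyphenyl groups of compound 3 remains open. So does the effect of an amine or a carboxylic acid at this position.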